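The source may hold more compounds than are shown below. What is called first, only, known or untested is meant among the compounds shown, and "the series" means these compounds.

Measured so far in an assay on isolated protein for activation of cGMP-dependent protein kinase 1 (Homo sapiens), read by ADP-Glo, with stated times of 30 min and 2 h, in the presence of a further agent that is not named here; on this read-out higher numbers stand for an effect only at larger amounts of compound and lower numbers for an effect already at smaller amounts: compound 1 `COC(=O)c1ccc(CN2CCC[C@H](O[C@H](CO)c3cc(Cl)cc(Cl)c3)[C@@H]2c2ccccc2)c(C)c1` gives 900 nM; compound 2 `Cc1cc(C(=O)O)ccc1CN1CCC[C@H](O[C@H](CO)c2cc(Cl)cc(Cl)c2)[C@@H]1c1ccc(F)cc1` gives 18000 nM; compound 3 `Cc1cc(C(=O)O)ccc1CN1CCC[C@H](O[C@H](CF)c2cc(Cl)cc(Cl)c2)[C@@H]1c1ccccc1` gives 9100 nM.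

Compound 1 stands lowest of the three numbers; compound 3 is nearest and compound 2 furthest, both beyond the scatter. Compounds 2 and 3 each differ from compound 1 in more than one place, so no single step can be read from them.

Compound 4 `Cc1nc(C(=O)O)ccc1CN1CCC[C@H](O[C@H](CO)c2cc(Cl)cc(Cl)c2)[C@@H]1c1ccccc1` differs from compound 1 by a group of 10 heavy atoms (7 carbon, 1 nitrogen, 2 oxygen; one six-membered aromatic ring with 1 hetero atom) in place of a group of 11 heavy atoms (9 carbon, 2 oxygen; one six-membered aromatic ring of carbon only), on a saturated chain carbon bound to an amine nitrogen in a ring. Among the compounds with values here, no measured pair isolates this change. Given that compound 1 carries the lowest number and both other members carry clearly higher ones, a step upward in this assay is expected for compound 4, moderate in size, estimated as a 5.6-fold higher number from compound 1 to compound 4 (0.74 log units; beyond the scatter). Compound 4 is expected to give about 5000 nM (range 1500 nM to 15000 nM).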

Compound 4, half-maximal effective concentration: 370 nM
Compound 4: the middle estimate sits 14-fold (1.13 log units) above what was measured; measured number below the stated range.
By their numbers in this assay, from the lowest: compound 4; then compound 1; then compounds 3 and 2 (each within the scatter of the next).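

In this assay, placing the group of 10 heavy atoms, with its six-membered aromatic ring with 1 hetero atom, on a saturated chain carbon bound to an amine nitrogen in a ring gives a 2.4-fold lower number from compound 1 to compound 4 (0.39 log units; beyond the scatter). The position therefore accepts this change, which also brings in a hydrogen-bond donor, without any loss in this assay. Nothing measured here accounts for the step.

Within the data shown here, the ring hetero atom and the donor enter together, so their separate shares cannot be read, and no step to compound 2 or compound 3 can be read either. As far as these compounds go, how a primary amide or a tetrazole would read on this ring remains open.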